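Triazole in place of methylamino on the shared core

The compounds below may be only part of what the source reports. "The series", "measured", "known", "first", "only" and "open" are said of these compounds alone.

Compound 2 `CNc1nc(NC)nc(NC2(C#N)CCCCC2)n1` gives 210 mL/min/kg in an ADME assay on microsomes from liver (Rattus norvegicus) for metabolic stability (on this read-out higher numbers stand for fast clearance and lower numbers for slow clearance), the highest of the three numbers measured. Compound 3 `CCCC(C#N)(CCC)Nc1nc(NC)nc(-n2cncn2)n1` gives 32 mL/min/kg in this assay, and compound 1 `CNc1nc(NC(C#N)(C2CC2)C2CC2)nc(-n2cncn2)n1` gives 3.7 mL/min/kg in this assay; both gaps to compound 2 lie beyond the scatter. Compound 4 `CNc1nc(NC2(C#N)CCCCC2)nc(-n2cnc(C)n2)n1` is not yet measured and carries 3-methyl-1H-1,2,4-triazol-1-yl in place of methylamino on an aromatic carbon. Among the compounds with values here, no measured pair isolates this change, and compound 4 also differs from compound 1 and compound 3 in the group bearing the nitrile, so the comparison is indirect. Still, the two compounds carrying a triazolyl group sit well below compound 2 in this assay. The expected downward step is estimated as a 5.3-fold lower number from compound 2 to compound 4 (0.72 log units; beyond the scatter). Compound 4 is estimated at 40 mL/min/kg, between 10 mL/min/kg and 130 mL/min/kg.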

Compound 4, clearance: > 276 mL/min/kg
Compound 4 gave a limit, no number; the forecaster's own chance of this, stated with the estimate: 5%; at least 6.9-fold (0.83 log units) between middle value and limit.
By their numbers in this assay, from the lowest: compound 1; then compound 3; then compound 2. At a limit, above all of these: compound 4.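

With the group bearing the nitrile unchanged, 3-methyl-1H-1,2,4-triazol-1-yl in place of methylamino on this aromatic carbon gives an at least 1.3-fold higher number from compound 2 to compound 4 (0.11 log units; that floor lies within the scatter) in this assay. Read on this pair alone, the change brings no drop in clearance at this position. Compound 4 gives a limit of the assay, not a number: the limit of > 276 mL/min/kg in this assay, at which 1 of the 4 values shown sits.

Going by these compounds, how far compound 4 lies past that limit stays open. Also open, on these data alone, is what a methoxy or dimethylamino group at this position would give on the same core.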